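Notes on replacing ethyl with tert-butyl

A few compounds are considered here, and "the series" means these few. Any claim that something is new, unique, unknown or untested is made for them only; others in the source may bear on it.

- compound 1 `CCc1ccccc1NC(N)=S`: > 10000 nM, a limit of the assay
- compound 2 `Cc1ccc(/C=N/NC(N)=S)cc1`: 6800 nM
- compound 3 `CCc1ccc(/C=N/NC(N)=S)cc1`: 3400 nM

In a functional assay on B16 cells (Mus musculus) for inhibition (on this read-out higher numbers stand for weaker inhibition and lower numbers for stronger inhibition), compound 2 gives 6800 nM and compound 3 gives 3400 nM, two values within the scatter of each other. Compound 1 reports only a limit. Compound 4 `CC(C)(C)c1ccc(/C=N/NC(N)=S)cc1` differs from compound 3 by tert-butyl in place of ethyl on an aromatic carbon, para to a group of 6 heavy atoms. Among the compounds with values here, one measured step bears on this change, a 2.0-fold lower number from compound 2 to compound 3 (0.30 log units; within the scatter), and it stays within the scatter. On that single step, no change beyond the scatter is expected, and the estimated step is a 1.1-fold lower number from compound 3 to compound 4 (0.05 log units; within the scatter). For compound 4 the expected value in this assay is 3000 nM, with an estimated range of 1200 nM to 8000 nM.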

Compound 4, half-maximal inhibitory concentration: 2700 nM
Compound 4: middle estimate off by 1.1-fold (0.05 log units), on the high side; low and high end bracket the measured number.
By their numbers in this assay, from the lowest: compounds 4, 3 and 2 (each within the scatter of the next, the first and the last beyond it). At a limit, above all of these: compound 1.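

On this aromatic carbon, para to a group of 6 heavy atoms, the larger tert-butyl is accepted in this assay: tert-butyl in place of ethyl gives a 1.3-fold lower number from compound 3 to compound 4 (0.10 log units; within the scatter). Against methyl, tert-butyl gives a 2.5-fold lower number from compound 2 to compound 4 (0.40 log units; beyond the scatter), the only step shown that lies beyond the scatter, and a modest one. Nothing available explains this step.

Open, as far as these compounds go, is how an amine, a carboxylic acid or a longer chain on this carbon would read out, and so whether the trend continues beyond tert-butyl.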